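The compounds below may be only part of what the source reports. "The series", "measured", "known", "first", "only" and "open" are said of these compounds alone.

Working notes on the series. Compound 1 `COc1cc2c(Oc3ccc(NC(=S)N/N=C/c4ccccc4)cc3F)ccnc2cc1OCCCN1CCCCC1` is the parent; in a functional assay on HT-29 cells (Homo sapiens) for cytotoxicity, read by MTT assay, with a stated time of 72 h (on this read-out lower numbers stand for stronger inhibition and higher numbers for weaker inhibition), compound 1 gives 210 nM. Compound 2 `COc1cc2c(Oc3ccc(NC(=S)N/N=C/c4ccc(Cl)cc4)cc3F)ccnc2cc1OCCCN1CCCCC1` carries chloro in place of hydrogen on an aromatic carbon, and in this assay compound 2 gives 190 nM. For the measured compounds named here, the step of a 1.1-fold lower number from compound 1 to compound 2 (0.04 log units; within the scatter) stays within the scatter, so the two measured compounds cannot be ordered; compound 2 merely holds the lower of the two numbers so far. Compound 3 `COc1cc2c(Oc3ccc(NC(=S)N/N=C/c4ccc(F)cc4Cl)cc3F)ccnc2cc1OCCCN1CCCCC1` is the next candidate; the change is 2-chloro-4-fluorophenyl in place of 4-chlorophenyl on a carbon with a double bond to nitrogen. Going by the values given here, the only measured step that bears on it is a 1.1-fold lower number from compound 1 to compound 2 (0.04 log units; within the scatter), also a halogen change, and it left the number essentially unmoved. No step beyond the scatter is therefore expected in this assay, in either direction. Compound 3 is expected at 200 nM, with a range of 90 nM to 450 nM. For compound 3 this implies an expected 1.1-fold higher number from compound 2 to compound 3 (0.02 log units; within the scatter).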

Compound 3, half-maximal inhibitory concentration: 420 nM
Estimate against measurement, compound 3: 2.1-fold (0.32 log units) below, and the stated range covers the measured number.
By their numbers in this assay, from the lowest: compounds 2, 1 and 3 (each within the scatter of the next, the first and the last beyond it).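

On the carbon with a double bond to nitrogen, the aryl group now gives its first step beyond the scatter in this assay: 2-chloro-4-fluorophenyl in place of 4-chlorophenyl gives a 2.2-fold higher number from compound 2 to compound 3 (0.34 log units; beyond the scatter), a modest change. Against the unsubstituted phenyl, the same group gives a 2.0-fold higher number from compound 1 to compound 3 (0.30 log units; within the scatter), which stays within the scatter, so this halogen pattern is separated only from the 4-chlorophenyl group and not from phenyl. Nothing measured here accounts for the step.

The compounds shown do not settle which part of the change carries the step, as 2-chloro-4-fluorophenyl and 4-chlorophenyl differ in more than one halogen feature. As far as these compounds go, how an amine or a carboxylic acid on this phenyl ring would read in this assay also stays open.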